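The source may hold more compounds than are shown below. What is called first, only, known or untested is meant among the compounds shown, and "the series" means these compounds.

Compound 1, `CCOC(=O)c1sc(-c2cccc(NC(=O)c3ccc(C(C)(C)C)cc3)c2)nc1Nc1ccc(N2CCN(C)CC2)cc1`, gives 21.2% in a functional assay on Ramos cells (Homo sapiens) for antiproliferative activity, read by CCK-8 assay, with a stated time of 72 h, tested at 40 uM; on this read-out higher numbers stand for more inhibition at the one concentration tested (going by the name of the read-out) and lower numbers for less inhibition. Compound 2, `CCOC(=O)c1sc(-c2cccc(NC(=O)c3ccccc3)c2)nc1Nc1ccc(N2CCN(C)CC2)cc1`, gives 77.1% in this assay. Compound 3, `CN1CCN(c2ccc(Nc3nc(-c4cccc(NC(=O)c5ccc(C(C)(C)C)cc5)c4)sc3C(N)=O)cc2)CC1`, gives 80.1% in this assay.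

The unmeasured compound 4 is `CN1CCN(c2ccc(Nc3nc(-c4cccc(NC(=O)c5ccccc5)c4)sc3C(N)=O)cc2)CC1`. It arises from compound 3 by one change, (hydrogen in place of tert-butyl on an aromatic carbon). The same change has been measured once already, from compound 1 to compound 2, where it gave a number 55.9 percentage points higher from compound 1 to compound 2 (beyond the scatter). The two starting points differ only in their cores: amino in place of ethoxy on a carbonyl carbon. The place of the change is described in the same words for both pairs. Because compound 3 already gives 80.1%, the room for a further rise is smaller than it was for compound 1, so the expected step in this assay is a number 5.9 percentage points higher from compound 3 to compound 4 (within the scatter), a rise but a modest one. Compound 4 is therefore expected to reach about 86%, most likely between 62% and 99%.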

Compound 4, a percentage reported as inhibition, at one concentration (the size of the read-out at that concentration, not a potency): 98.1%
Compound 4: the middle estimate sits 12.1 percentage points below what was measured; low and high end bracket the measured number.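

In this assay, going from 4-(tert-butyl)phenyl to phenyl on the core of compound 3 gives a number 18 percentage points higher from compound 3 to compound 4 (beyond the scatter), so the direction carries over from the other core but the size does not: the same change on two cores in this assay, a number 55.9 percentage points higher (beyond the scatter) from compound 1 to compound 2 and a number 18 percentage points higher (beyond the scatter) from compound 3 to compound 4, 37.9 percentage points apart, beyond the scatter of two such steps

With the phenyl in place, amino instead of ethoxy on the carbonyl gives a number 21 percentage points higher from compound 2 to compound 4 (beyond the scatter), so this change also keeps its direction but not its size: the same change on two cores in this assay, a number 58.9 percentage points higher (beyond the scatter) from compound 1 to compound 3 and a number 21 percentage points higher (beyond the scatter) from compound 2 to compound 4, 37.9 percentage points apart, beyond the scatter of two such steps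

The effects of the two changes therefore do not simply add up, but these readings at a single concentration do not show why, and they do not measure potency.

The compounds shown leave open what methyl or chloro would give in place of the tert-butyl. They also leave open how a carboxylic acid in place of the ethoxy would compare.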